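The source may hold more compounds than are shown below. What is called first, only, known or untested is meant among the compounds shown, and "the series" means these compounds.

Working notes on the series in an ADME assay on Vero cells (Chlorocebus sabaeus) for cytotoxicity, with a stated time of 72 h; a lower number here means a stronger inhibitor, a higher number a weaker inhibitor.

Compound 3 `O=[N+]([O-])c1cn2c(n1)OC[C@@H](OCc1ccc(-c3ccc(F)cc3)s1)C2` is one of three close analogues that share one core and differ only in the group on the distal six-membered ring. In this assay compound 3 gives only a limit, > 128000 nM. Compound 1 `O=[N+]([O-])c1cn2c(n1)OC[C@@H](OCc1ccc(-c3ccc(C(F)(F)F)cc3)s1)C2` likewise gives only a limit, > 128000 nM. Compound 2 `N#Cc1ccc(-c2ccc(CO[C@@H]3COc4nc([N+](=O)[O-])cn4C3)s2)cc1` also gives only a limit, > 128000 nM. Going by the values given here, all three therefore stand at the same place, namely (the limit of > 128000 nM in this assay, at which 3 of the 3 values shown sit), and none of the measured steps can be read: a step that the two limits leave unreadable from compound 1 to compound 2, a step that the two limits leave unreadable from compound 1 to compound 3 and a step that the two limits leave unreadable from compound 2 to compound 3 are each left open by the two limits.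

Compound 4 `O=[N+]([O-])c1cn2c(n1)OC[C@@H](OCc1ccc(-c3ccc(OC(F)(F)F)cc3)s1)C2` is not yet measured. It differs from compound 3 by trifluoromethoxy in place of fluoro on an aromatic carbon. Of the measured steps, the ones from compound 1 to compound 3 and from compound 2 to compound 3 touch the same position, and both are unreadable; they give no size and no direction. Because every value shown sits at the limit of > 128000 nM in this assay, at which 3 of the 3 values shown sit, the expectation for compound 4 is that this assay again reports a limit, so the step that the limit leaves unreadable from compound 3 to compound 4 is expected to be nil within what the assay can resolve. Compound 4 is accordingly estimated at 200000 nM, with a range from 100000 nM to 600000 nM.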

Compound 4, half-maximal inhibitory concentration: > 128000 nM
Compound 4: no number, only a limit; the forecaster's own chance of this, stated with the estimate: 90%; the middle value does not contradict the limit.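

In this assay compound 4 gives only a limit, > 128000 nM, so its steps to compound 1, compound 2 and compound 3 cannot be read: the limit of > 128000 nM in this assay, at which 4 of the 4 values shown sit.

The compounds shown leave open whether the group on the distal six-membered ring makes any difference in this assay.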